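The source may hold more compounds than are shown below. What is called first, only, known or untested is meant among the compounds shown, and "the series" means these compounds.

Measured compounds:
- Compound 1, `O=C(COc1ccc2cc(/C=C3/SC(=O)NC3=O)ccc2c1)Nc1cccc(Cl)c1`, in an assay on isolated protein for inhibition of histone deacetylase 4 (Homo sapiens), with a stated time of 1 h (a lower number here means a stronger inhibitor, a higher number a weaker inhibitor), compound 1 gives 3800 nM.
- Compound 2, `Cc1cccc(NC(=O)COc2ccc3cc(/C=C4/SC(=O)NC4=O)ccc3c2)n1`, in this assay compound 2 gives 1100 nM.

Of the two numbers, compound 1 has the highest, so it is the weaker inhibitor of the pair; its nearest neighbour is compound 2, reached by a 3.5-fold lower number from compound 1 to compound 2 (0.54 log units; beyond the scatter), where 6-methylpyridin-2-yl replaces 3-chlorophenyl on an amide-type nitrogen.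

Compound 3, `O=C(COc1ccc2cc(/C=C3/SC(=O)NC3=O)ccc2c1)Nc1c(F)cc(F)cc1Br`, has not yet been measured in this assay. It differs from compound 1 in one place: 2-bromo-4,6-difluorophenyl in place of 3-chlorophenyl on an amide-type nitrogen. Going by the values given here, the only measured step that touches this position is the one from compound 1 to compound 2, a 3.5-fold lower number from compound 1 to compound 2 (0.54 log units; beyond the scatter), and it shows that the group on the amide-type nitrogen can shift the number by a modest amount. That step, however, brought in a pyridine-type ring, whereas compound 3 keeps a ring of carbon only and changes its halogens, so it gives no direction for the present change. Compound 3 is therefore expected to stay near compound 1, with a 1.3-fold lower number from compound 1 to compound 3 (0.10 log units; within the scatter) likely within the scatter. The estimate for compound 3 is 3000 nM, in the range 900 nM to 10000 nM.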

Compound 3, half-maximal inhibitory concentration: 1100 nM
The estimate for compound 3 lay 2.7-fold (0.44 log units) above the measured number; measured number inside the range.
By their numbers in this assay, from the lowest: compounds 2 and 3 (each within the scatter of the next); then compound 1.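

In this assay, the change to 2-bromo-4,6-difluorophenyl on the amide-type nitrogen gives a 3.5-fold lower number from compound 1 to compound 3 (0.54 log units; beyond the scatter). This shows that the number can fall at this position while the ring stays carbon only, something the earlier step could not show, as it also brought a nitrogen into the ring. The pyridine-type ring of compound 2 is thus not required to reach this level, since the step between the two groups shows no change at the digits printed from compound 2 to compound 3 (within the scatter), even though they carry different atoms; no measurement here helps to explain the drop from compound 1.

The change removes one chlorine and brings in one bromine and two fluorines in a single move, so the compounds shown cannot say which of these halogens matters, or whether the halogens must act together. Also open, going by these compounds, is how the number would respond to a phenyl ring with no halogen at all, or to a phenyl ring carrying a methoxy group, an amine or a carboxylic acid on this same amide-type nitrogen.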